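This account rests on a few compounds, and the source may have more. Where it says the series, first, only, none or still open, it means among the compounds named here.

Values in a functional assay on K562 cells (Homo sapiens) for cytotoxicity, read by fluorescence, with a stated time of 72 h (on this read-out higher numbers stand for weaker inhibition and lower numbers for stronger inhibition), so far
- Compound 1 `CC(C)c1n[nH]c2c(NCc3ccc(-c4ccccn4)cc3)nc(S(C)(=O)=O)nc12` gives 640 nM
- Compound 2 `CC(C)c1n[nH]c2c(NCc3ccc(-c4ccccn4)cc3)nc(N[C@@H]3CCCC[C@H]3N)nc12` gives 175 nM
- Compound 3 `CC(C)c1n[nH]c2c(NCc3ccc(-c4ccccn4)cc3)nc(NCCN(C)C)nc12` has not been measured

For the measured compounds named here, compound 2 has the lower of the two numbers, and compound 1 is its only measured neighbour. Going by the values given here, the single measured step, a 3.7-fold lower number from compound 1 to compound 2 (0.56 log units; beyond the scatter) in size, put (2-aminocyclohexyl)amino in place of methylsulfonyl on an aromatic carbon. Compound 3 changes the group at that same place, with 2-(dimethylamino)ethyl in place of 2-aminocyclohexyl on a nitrogen on an aromatic ring. The step to compound 2 shows only that this place can shift the number. Among the compounds with values here, no measured compound carries the new group, so the direction is uncertain. A small rise in this assay is expected, perhaps within the scatter. The expected change is a 1.6-fold higher number from compound 2 to compound 3 (0.20 log units; within the scatter) on this estimate. For compound 3 the estimate is 280 nM with an expected range from 100 nM to 800 nM in this measurement.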

Compound 3, half-maximal inhibitory concentration: 125 nM
Compound 3: the middle estimate sits 2.2-fold (0.35 log units) above what was measured; the range from low to high includes it.
By their numbers in this assay, from the lowest: compounds 3 and 2 (each within the scatter of the next); then compound 1.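

Replacing 2-aminocyclohexyl with 2-(dimethylamino)ethyl on the nitrogen gives a 1.4-fold lower number from compound 2 to compound 3 (0.15 log units; within the scatter) in this assay and so leaves the number within the scatter. At this position, then, the six-membered ring and its defined stereocentres can give way to an open chain, and the entering group carries no hydrogen-bond donor, without a change that can be told apart from the scatter. Against methylsulfonyl, the new group gives a 5.1-fold lower number from compound 1 to compound 3 (0.71 log units; beyond the scatter) as a step beyond the scatter, so two different amino groups now stand on the same side of compound 1.

From the compounds shown here alone, whether a longer chain on this nitrogen, or a carboxylic acid in place of the dimethylamino end, would keep the number in this range stays open. Nothing available explains why these two amino groups read so alike.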